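Aryl swaps on a shared core against lung cancer cells

A few compounds are considered here, and "the series" means these few. Any claim that something is new, unique, unknown or untested is made for them only; others in the source may bear on it.

Compound 1, `COC(=O)c1sc2cc(-c3cnn(C)c3)cnc2c1N`: > 150000 nM
Compound 2, `COC(=O)c1sc2cc(-c3cccnc3)cnc2c1N`: > 112000 nM
Compound 3, `COC(=O)c1sc2cc(-c3ccc(F)nc3)cnc2c1N`: "not determined" (no result reported)

In a functional assay on NCI-H460 cells (Homo sapiens) for inhibition, read by sulforhodamine B assay, with a stated time of 48 h (on this read-out lower numbers stand for stronger inhibition of growth and higher numbers for weaker inhibition of growth), compound 1 gives > 150000 nM, which is a limit of the assay and not a number. Compound 2 gives > 112000 nM, again a limit. Compound 3 has no result at all, its entry reading "not determined" (no result reported), so it stands nowhere on the numbers shown. Among the measured compounds shown here, the only measured step, a step that the two limits leave unreadable from compound 1 to compound 2, is unreadable because the limit of > 112000 nM in this assay, at which 1 of the 3 values shown sits, and the limit of > 150000 nM in this assay, at which 1 of the 3 values shown sits, sit at its two ends. Compound 4, `COC(=O)c1sc2cc(-c3cccc(N)c3)cnc2c1N`, differs from compound 3 by 3-aminophenyl in place of 6-fluoropyridin-3-yl on an aromatic carbon. No measured step bears on this change, and the one step shown gives no size at all, so no direction beyond the scatter can be read from the data. Compound 4 is therefore expected to give about 100000 nM, within 20000 nM to 300000 nM, and most probably only a limit once more.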

Compound 4, concentration for 50% growth inhibition: > 150000 nM
Compound 4: no number, only a limit; the forecaster's own chance of this, stated with the estimate: 70%; at least 1.5-fold (0.17 log units) between middle value and limit.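

Among the compounds shown here, no step from compound 1 or compound 2 to compound 4 can be read, as all three compounds stand only as limits. The compounds shown leave open how far any of these aryl swaps changes growth inhibition, and where compound 3 stands.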